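The compounds below may be only part of what the source reports. "The series", "measured", "known", "first", "only" and "open" are said of these compounds alone.

Measured compounds in a functional assay on MIA PaCa-2 cells (Homo sapiens) for inhibition, read by MTT assay, with a stated time of 72 h; on this read-out lower numbers stand for stronger inhibition of growth and higher numbers for weaker inhibition of growth:
Compound 1 `Cc1ccc(C)c(S(=O)(=O)NCCCCCCNCc2ccc(Br)cc2)c1` gives 12000 nM
Compound 2 `CC(C)(C)c1ccc(CNCCCNS(=O)(=O)c2cc(C(F)(F)F)cc(C(F)(F)F)c2)cc1` gives 2300 nM
Compound 3 `O=S(=O)(NCCCNCc1ccc(-c2ccccc2)cc1)c1cc(C(F)(F)F)cc(C(F)(F)F)c1` gives 2400 nM

Among these three, compound 2 gives the lowest number, but only its gap to compound 1 is beyond the scatter; its gap to compound 3 is not, so the two cannot be ranked against each other. Compound 4 `O=S(=O)(NCCCNCc1ccc(Cl)c(Cl)c1)c1cc(C(F)(F)F)cc(C(F)(F)F)c1` has not yet been measured. It differs from compound 2 in one place: 3,4-dichlorophenyl in place of 4-(tert-butyl)phenyl on a saturated chain carbon bound to an amine nitrogen. Cut one bond further out, the same change reads 4-(tert-butyl)benzyl to 3,4-dichlorobenzyl.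

Going by the values given here, only one measured step touches this position. The step of a 1.0-fold higher number from compound 2 to compound 3 (0.02 log units; within the scatter) shows that replacing tert-butyl by phenyl leaves the number essentially unchanged, so this part of the molecule appears tolerant of change, at least for that pair. Among the compounds with values here, no measured step introduces chlorine here, so the expectation rests on that single comparison. Compound 4 is therefore expected to stay close to compound 2, with a step of a 1.3-fold higher number from compound 2 to compound 4 (0.12 log units; within the scatter) that is estimated to lie within the scatter. The estimate for compound 4 in this assay is 3000 nM, with a range from 1200 nM to 8000 nM.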

Compound 4, concentration for 50% growth inhibition: 2700 nM
Estimate against measurement, compound 4: 1.1-fold (0.05 log units) above, and the stated range covers the measured number.
By their numbers in this assay, from the lowest: compounds 2, 3 and 4 (each within the scatter of the next); then compound 1.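

In this assay, putting 3,4-dichlorophenyl in place of 4-(tert-butyl)phenyl gives a 1.2-fold higher number from compound 2 to compound 4 (0.07 log units; within the scatter). Going by these compounds alone, until now, the only change seen at this position was tert-butyl to phenyl, so the tolerance rested on a single pair; it now also covers a group that carries two chlorine atoms and has fewer heavy atoms than 4-(tert-butyl)phenyl. Nothing measured here gives a reason for this tolerance.

Still open is whether this position would also accept a ring bearing a carboxylic acid or an amine, since all the groups shown here carry only carbon or chlorine on the ring. Compound 1 differs from the others in more than one place, so the effect of its longer chain between the two nitrogens cannot be read on its own.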